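Methoxy in Place of Fluoro: Expected Cytotoxicity of Compound 4

The source may report more compounds than this note shows. Statements on the series, on what has been measured and on what is new or still open speak of the compounds shown alone.

Measured compounds:
compound 1 `O=C1COc2ccc(-c3[nH]c(-c4ccc(C(F)(F)F)cc4)nc3-c3ccccc3)cc2N1` — 103%
compound 2 `O=C1COc2ccc(-c3nn(-c4ccc(Br)cc4)cc3-c3ccccc3)cc2N1` — 81.5%
compound 3 `O=C1COc2ccc(-c3nn(-c4ccc(F)cc4)cc3-c3ccccc3)cc2N1` — 78.2%

In a functional assay on A549 cells (Homo sapiens) for cytotoxicity, read by colorimetric assay and MTT assay, with a stated time of 3 days, tested at 1 uM (on this read-out lower numbers stand for a stronger effect and higher numbers for a weaker effect at the one concentration tested), compound 3 gives 78.2%, the lowest of the three numbers; compound 2 sits within the scatter of it, while compound 1 sits beyond the scatter above it. Compound 4 `COc1ccc(-n2cc(-c3ccccc3)c(-c3ccc4c(c3)NC(=O)CO4)n2)cc1` differs from compound 3 in a single place: methoxy in place of fluoro on an aromatic carbon. Among the measured compounds shown here, the only measured step touching this position, a number 3.3 percentage points lower from compound 2 to compound 3 (within the scatter), stayed within the scatter, and no measured step exchanges fluoro for methoxy, so that part of the change has no precedent here. A change of similar size is therefore expected, with no direction beyond the scatter. The estimate for compound 4 is 80%, with a range from 65% to 95%. This amounts to an expected step of a number 1.8 percentage points higher from compound 3 to compound 4 (within the scatter).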

Compound 4, a percentage reported as activity, at one concentration (the size of the read-out at that concentration, not a potency): 95.6%
Estimate against measurement, compound 4: 15.6 percentage points below; the measured number lies above the stated range.
By their numbers in this assay, from the lowest: compounds 3 and 2 (each within the scatter of the next); then compounds 4 and 1 (each within the scatter of the next).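

In this assay this position proved able to shift the read-out: bromo and fluoro had stayed within the scatter of each other, but 4-methoxyphenyl brought a number 17.4 percentage points higher from compound 3 to compound 4 (beyond the scatter) and likewise a number 14.1 percentage points higher from compound 2 to compound 4 (beyond the scatter) on the same ring carbon. Methoxy in place of either halogen therefore weakened the effect at the one concentration tested. Nothing available accounts for this difference. The compounds shown leave open whether a hydroxy group or an amine here would read like bromo and fluoro or like methoxy. They also leave open how a longer chain such as ethoxy would read.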